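Carbonyl substituent exchange from compound 2 to compound 3

The source may hold more compounds than are shown below. What is called first, only, known or untested is meant among the compounds shown, and "the series" means these compounds.

In a functional assay on EBC-1 cells (Homo sapiens) for antiproliferative activity, with a stated time of 72 h (on this read-out lower numbers stand for stronger inhibition and higher numbers for weaker inhibition), compound 1 (`N#Cc1cccc(-c2cc(F)c3ncc(Cc4ccc5ncccc5c4)n3c2)c1`) gives 107 nM as its value, while compound 2 (`O=C(c1ccc(-c2cc(F)c3ncc(Cc4ccc5ncccc5c4)n3c2)cc1F)N1CCC2(COC2)C1`) gives 406 nM and so holds the higher, weaker number of the two, with a gap beyond the scatter. Compound 3 (`O=C(NC1CCCNC1)c1ccc(-c2cc(F)c3ncc(Cc4ccc5ncccc5c4)n3c2)cc1F`) keeps the core of compound 2 and differs only on a carbonyl carbon. The structural change is a group of 7 heavy atoms (5 carbon, 2 nitrogen; one six-membered non-aromatic ring with 1 hetero atom) in place of a group of 8 heavy atoms (6 carbon, 1 nitrogen, 1 oxygen; one four-membered non-aromatic ring with 1 hetero atom, one five-membered non-aromatic ring with 1 hetero atom), on a carbonyl carbon with (piperidin-3-yl)amino as the entering group. Among the measured compounds shown here, no measured pair isolates such a change, so the expectation rests on compound 2 at 406 nM alone and stays wide. In this assay the expected change is small, with a 1.6-fold lower number from compound 2 to compound 3 (0.21 log units; within the scatter) as the estimate, and it is not expected to exceed the scatter. For compound 3 the estimated value is 250 nM with an expected range from 70 nM to 900 nM as the likely span.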

Compound 3, half-maximal inhibitory concentration: 138 nM
Compound 3: the middle estimate sits 1.8-fold (0.26 log units) above what was measured; the range from low to high includes it.
By their numbers in this assay, from the lowest: compounds 1 and 3 (each within the scatter of the next); then compound 2.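

In this assay, among the compounds shown here, the carbonyl carbon gives the first single-place comparison: (piperidin-3-yl)amino in place of the group with the four-membered and five-membered non-aromatic rings gives a 2.9-fold lower number from compound 2 to compound 3 (0.47 log units; beyond the scatter) on the shared core. The read-out therefore responds to the group on this carbonyl carbon, though the exchange alters ring content, heteroatoms and hydrogen-bond donor count together, and this single step cannot separate them. No available evidence accounts for the step.

The compounds shown leave open whether the lower number goes with the amide hydrogen, the piperidine ring or its ring nitrogen. A dimethylamine amide, a morpholine amide or a carboxylic acid on the same carbonyl carbon would help to separate these features.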